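This account rests on a few compounds, and the source may have more. Where it says the series, first, only, none or still open, it means among the compounds named here.

In a functional assay on VCaP cells (Homo sapiens) for antiproliferative activity, read by CCK-8 assay, with a stated time of 6 days (on this read-out lower numbers stand for stronger inhibition and higher numbers for weaker inhibition), compound 1 `C[C@@H](Cn1ccc(-c2ccc(C#N)c(Cl)c2)n1)NS(=O)(=O)c1cccnc1` gives 2450 nM. Compound 2 `C[C@@H](Cn1ccc(-c2ccc(C#N)c(Cl)c2)n1)Nc1cccnc1` gives > 30000 nM, which is a limit of the assay and not a number. For the measured compounds named here, replacing the (pyridin-3-yl)sulfonyl on the amine nitrogen with pyridin-3-yl is the only measured step, an at least 12-fold higher number from compound 1 to compound 2 (1.08 log units; beyond the scatter). Compound 3 `C[C@@H](Cn1ccc(-c2ccc(C#N)c(Cl)c2)n1)Nc1ccccn1` has no number to stand on, its entry reading "not determined" (no result reported). Compound 4 `C[C@@H](Cn1ccc(-c2ccc(C#N)c(Cl)c2)n1)Nc1ccncc1` differs from it by pyridin-4-yl in place of pyridin-2-yl on an amine nitrogen. No step size from compound 3 can therefore be stated, and the measured step bears only indirectly. Compound 4, like compound 2, lacks the sulfonyl, so it is expected to remain much weaker than compound 1, given an at least 12-fold higher number from compound 1 to compound 2 (1.08 log units; beyond the scatter). For compound 4 the expected value in this assay is about 25000 nM, with an estimated range of 7000 nM to 40000 nM.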

Compound 4, half-maximal inhibitory concentration: 9900 nM
Estimate against measurement, compound 4: 2.5-fold (0.40 log units) above; the range from low to high includes it.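

In this assay pyridin-4-yl in place of pyridin-3-yl on the amine nitrogen gives an at least 3.0-fold lower number from compound 2 to compound 4 (0.48 log units; beyond the scatter) and so shows that the attachment point of the pyridine alone changes the result once the sulfonyl is gone. Pyridin-4-yl in place of (pyridin-3-yl)sulfonyl still gives a 4.0-fold higher number from compound 1 to compound 4 (0.61 log units; beyond the scatter) in this series, so compound 4 does not recover the number of compound 1. The first step is open-ended, since the value of compound 2 is a limit of the assay and not a number: the limit of > 30000 nM in this assay, at which 1 of the 4 values shown sits.

Steps involving compound 3 cannot be read, which leaves pyridin-2-yl unplaced. Also open, going by these compounds, is how (pyridin-4-yl)sulfonyl or phenyl on the amine nitrogen would compare.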